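The compounds below may be only part of what the source reports. "The series", "measured", "known", "first", "only" and "open" are said of these compounds alone.

Two compounds from this series carry measured values in a toxicity assay on MT4 cells (Homo sapiens) for cytotoxicity, read by MTT assay, with a stated time of 5 days; a lower number here means that less compound is tolerated, a higher number that more compound is tolerated. Compound 1, `CCOC(=O)c1ccc(NC(=O)CSc2nnc(COc3ccc(NC(C)=O)cc3)n2Cc2ccccc2)cc1`, gives 91.1 ug/mL in this assay. Compound 2, `O=C(CSc1nnc(COc2ccc3ccccc3c2)n1Cc1ccccc1)Nc1ccc([N+](=O)[O-])cc1`, reaches only a limit of this assay, reported as >= 116 ug/mL. That reading sits at the limit of >= 116 ug/mL in this assay, at which 1 of the 2 values shown sits, so the tolerated amount for compound 2 is not fixed to a number, only bounded. Compound 1 and compound 2 differ from each other in more than one place, so their readings are simply set side by side here without any step drawn between them. Compound 3, `CCOC(=O)c1ccc(NC(=O)CSc2nnc(COc3ccc4ccccc4c3)n2Cc2ccccc2)cc1`, is not yet measured. It differs from compound 2 in a single place: ethoxycarbonyl in place of nitro on an aromatic carbon. Compound 1 already carries the ethoxycarbonyl group on the same aromatic carbon of its shared core, which gives some footing for what compound 3 may show. The step of an at least 1.2-fold lower number from compound 2 to compound 3 (0.08 log units; that floor lies within the scatter) is expected to be small, not clearly beyond the scatter, with a lean toward a somewhat lower tolerated amount. Compound 3 is expected to give 95 ug/mL in this assay. For compound 3 the expected range runs from 50 ug/mL to 150 ug/mL.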

Compound 3, half-maximal cytotoxic concentration: >= 90.7 ug/mL
Compound 3: no number, only a limit; the forecaster's own chance of this, stated with the estimate: 35%; the middle value does not contradict the limit.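

In this assay compound 3 gives only a limit, >= 90.7 ug/mL. No step can be read from compound 2 to compound 3 or from compound 1 to compound 3. The compounds shown leave open whether ethoxycarbonyl in place of nitro, or naphthalen-2-yl in place of 4-acetamidophenyl, changes the tolerated amount at all, and by how much.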